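The compounds below may be only part of what the source reports. "The series", "measured", "known", "first", "only" and "open" are said of these compounds alone.

Measured compounds:
- Compound 1, `O=[N+]([O-])c1ccc(CN2CCC(n3cc(CC(OCc4cc(-c5ccc(Br)cc5)no4)c4ccc(Br)cc4)nn3)CC2)cc1`, gives 3000 nM in a functional assay on Caco-2 cells (Homo sapiens) for cytotoxicity, with a stated time of 48 h; a higher number here means a weaker inhibitor, a lower number a stronger inhibitor.
- Compound 2, `O=[N+]([O-])c1ccc(CN2CCC(n3cc(CC(OCc4cc(-c5cccc(Br)c5)no4)c4ccc(Br)cc4)nn3)CC2)cc1`, gives 5000 nM in this assay.
- Compound 3, `O=[N+]([O-])c1ccc(CN2CCC(n3cc(CC(OCc4cc(-c5cccc(F)c5)no4)c4ccc(Br)cc4)nn3)CC2)cc1`, gives 5000 nM in this assay.

For the measured compounds named here, compound 3 stands level with compound 2 at the digits given, the two together the highest of the three numbers; the only other number belongs to compound 1, and that gap is a 1.7-fold higher number from compound 1 to compound 3 (0.22 log units; within the scatter). Compound 4, `COc1cccc(-c2cc(COC(Cc3cn(C4CCN(Cc5ccc([N+](=O)[O-])cc5)CC4)nn3)c3ccc(Br)cc3)on2)c1`, carries one change against compound 3: methoxy in place of fluoro on an aromatic carbon. Going by the values given here, no measured step swaps fluoro for methoxy. The steps that alter the same ring are a 1.7-fold higher number from compound 1 to compound 2 (0.22 log units; within the scatter), a 1.7-fold higher number from compound 1 to compound 3 (0.22 log units; within the scatter) and no change at the digits printed from compound 2 to compound 3 (within the scatter), each within the scatter. On that basis the expected step is no change at the digits printed from compound 3 to compound 4 (within the scatter), nothing beyond the scatter. Compound 4 is therefore estimated at 5000 nM, within 2500 nM to 10000 nM.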

Compound 4, half-maximal inhibitory concentration: 5000 nM
Compound 4: middle estimate and measured number agree at the digits printed, within the range that was stated.
By their numbers in this assay, from the lowest: compounds 1, 2, 3 and 4 (each within the scatter of the next).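

In this assay the 3-methoxyphenyl compound reads like the halogen-bearing ones (no change at the digits printed from compound 3 to compound 4 (within the scatter); no change at the digits printed from compound 2 to compound 4 (within the scatter); a 1.7-fold higher number from compound 1 to compound 4 (0.22 log units; within the scatter)). This ring position, shown until now only with bromo or fluoro, therefore also takes methoxy, with two heavy atoms and a hydrogen-bond acceptor, without a step beyond the scatter. No measured information gives a reason for this. As far as these compounds go, whether an amine or a carboxylic acid on this ring would give a step beyond the scatter stays open.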